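Adding a Second Chloro Group: Expected Cytotoxicity

The source may hold more compounds than are shown below. What is called first, only, known or untested is meant among the compounds shown, and "the series" means these compounds.

Of the compounds shown here, two sharing one core have been tested in a functional assay on PC-12 cells (Rattus norvegicus) for cytotoxicity, read by MTT assay, with stated times of 3 h and 2 h, tested at 1 uM; a lower number here means a weaker effect, a higher number a stronger effect of the compound at the concentration tested. Compound 1 `O=C(CCCCC1CCSS1)NCc1cn(CCCOc2ccc3cc(-c4ccccc4)c(=O)oc3c2)nn1` is the starting point; in this assay compound 1 gives 31.9%. Compound 2 `O=C(CCCCC1CCSS1)NCc1cn(CCCOc2ccc3cc(-c4ccc(Cl)cc4)c(=O)oc3c2)nn1` differs from it by a single chlorine, and in this assay compound 2 gives 49.3%. That exchange produced a number 17.4 percentage points higher from compound 1 to compound 2 (beyond the scatter), so compound 2 stands highest of the two numbers, with compound 1 the nearest one below it.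

Compound 3 `O=C(CCCCC1CCSS1)NCc1cn(CCCOc2ccc3cc(-c4ccc(Cl)c(Cl)c4)c(=O)oc3c2)nn1` carries one further change: chloro in place of hydrogen on an aromatic carbon. Read one bond further out, the 4-chlorophenyl of compound 2 becomes 3,4-dichlorophenyl. Among the compounds with values here, the only step that bears on this is the one from compound 1 to compound 2, where the same kind of exchange, a chloro in place of a hydrogen on an aromatic carbon, raised the read-out modestly and beyond the scatter. A second chlorine need not repeat that gain in full, but a rise of similar or smaller size is the reasonable expectation. Compound 3 is therefore expected to show a number 8.7 percentage points higher from compound 2 to compound 3 (within the scatter). Compound 3 is estimated at 58%, with a range from 42% to 74%.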

Compound 3, a percentage reported as activity, at one concentration (the size of the read-out at that concentration, not a potency): 42.4%
Beside the measured number, compound 3's estimate is 15.6 percentage points above it; measured number inside the range.
By their numbers in this assay, from the lowest: compound 1; then compounds 3 and 2 (each within the scatter of the next).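

In this assay, placing a second chloro on the aromatic carbon ortho to the first chloro group gives a number 6.9 percentage points lower from compound 2 to compound 3 (within the scatter), so the 4-chlorophenyl and 3,4-dichlorophenyl groups cannot be told apart by this read-out. The first chlorine gave a gain beyond the scatter, but the second adds none that can be distinguished, so chlorine here does not act as a simple ladder in which each added atom raises the number. The 3,4-dichlorophenyl group does remain separated from plain phenyl, with a number 10.5 percentage points higher from compound 1 to compound 3 (beyond the scatter) as the overall step, and this separation is no larger than the one seen with the single chlorine. Nothing measured here explains why the second chlorine adds no clear gain.

On these data alone, what other groups would do on this same carbon remains open, whether a bromo, a methoxy, an amine or a carboxylic acid. Also open, as far as these compounds go, is whether the two chlorinated compounds would stay this close in this assay at concentrations other than the single one reported.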